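The compounds below may be only part of what the source reports. "The series", "measured", "known", "first", "only" and "open" are said of these compounds alone.

Measured compounds:
- compound 2, `C=CCN1C(=O)S/C(=C\c2cn(-c3ccccc3)nc2-c2ccccc2)C1=O`: 50000 nM
- compound 3, `C=CCN1C(=O)S/C(=C\c2cn(-c3ccccc3)nc2-c2ccc(Cl)cc2)C1=O`: 10000 nM
- compound 1, `O=C1NC(=O)/C(=C/c2cn(-c3ccccc3)nc2-c2ccc(Cl)cc2)S1`: "not evaluated" (no result reported) in a functional assay on SH-SY5Y cells (Homo sapiens) for inhibition, with stated times of 48 h and 72 h; on this read-out higher numbers stand for weaker inhibition and lower numbers for stronger inhibition

Compound 1 carries the ring nitrogen unsubstituted and was not taken through this assay. Among the two compounds with a number, compound 3 holds the lower one: the single measured step, a 5.0-fold lower number from compound 2 to compound 3 (0.70 log units; beyond the scatter), separates it from compound 2, and it lies beyond the scatter.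

Compound 4, `O=C1S/C(=C\c2cn(-c3ccccc3)nc2-c2ccc(Cl)cc2)C(=O)N1Cc1ccccc1`, differs from compound 3 in one place: phenyl in place of vinyl on a saturated chain carbon bound to an amide-type nitrogen in a ring. Going by the values given here, no measured step touches this position; the only step known, from compound 2 to compound 3, concerns the chloro on the aromatic carbon and says nothing about the group on the ring nitrogen. With no guide from the data, the expectation for the step from compound 3 to compound 4 is that it stays within the scatter, no change at the digits printed from compound 3 to compound 4 (within the scatter). Compound 4 is therefore estimated at 10000 nM in this assay, with a range from 3000 nM to 35000 nM.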

Compound 4, half-maximal inhibitory concentration: 8000 nM
The estimate for compound 4 lay 1.3-fold (0.10 log units) above the measured number, and the stated range covers the measured number.
By their numbers in this assay, from the lowest: compounds 4 and 3 (each within the scatter of the next); then compound 2.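

In this assay, going by these compounds alone, the first measured step at the group on the ring nitrogen, allyl to benzyl, gives a 1.3-fold lower number from compound 3 to compound 4 (0.10 log units; within the scatter), so exchanging the vinyl for a phenyl on the saturated chain carbon leaves no change that can be told from the scatter. The chloro step, a 5.0-fold lower number from compound 2 to compound 3 (0.70 log units; beyond the scatter), lies beyond the scatter, so among the compounds shown only the aromatic chloro moves the number, while this larger group with its six-membered aromatic ring does not. Nothing measured here bears on why allyl and benzyl read alike.

Going by these compounds, whether a longer chain such as phenethyl, or an amine or a carboxylic acid carried on this chain, would shift the number remains open. So does whether the chloro step holds when benzyl stands on the ring nitrogen.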